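Phenyl for Methyl on the Amide Carbonyl: Compound 4

The source may hold more compounds than are shown below. What is called first, only, known or untested is meant among the compounds shown, and "the series" means these compounds.

Compound 1 `O=C(CSc1nc2ccc(NC(=O)CCl)cc2s1)NCc1ccc(Cl)cc1` gives 4900 nM in a functional assay on MCF7 cells (Homo sapiens) for cytotoxicity, read by MTT assay, with a stated time of 48 h; on this read-out higher numbers stand for weaker inhibition and lower numbers for stronger inhibition.
Compound 2 `CNC(=O)CSc1nc2ccc(NC(=O)c3ccccc3)cc2s1` gives 34400 nM.
Compound 3 `CC(=O)Nc1ccc2nc(SCC(=O)NCc3ccc(Cl)cc3)sc2c1` gives 10200 nM.

Compound 3 holds the second highest number of the three: compound 1 sits at a lower number and compound 2 at a higher one. Compound 4 `O=C(CSc1nc2ccc(NC(=O)c3ccccc3)cc2s1)NCc1ccc(Cl)cc1` differs from compound 3 by phenyl in place of methyl on a carbonyl carbon, acetamido becoming benzamido. Within the data shown here, the only single-point step measured, a 2.1-fold higher number from compound 1 to compound 3 (0.32 log units; beyond the scatter), concerns the saturated chain carbon and says nothing about the group on the carbonyl carbon. Compound 2 also carries benzamido, yet its amide differs as well, so its higher number cannot be laid to one change. Lacking a step bearing on this swap, compound 4 is expected to land close to compound 3, a 1.2-fold higher number from compound 3 to compound 4 (0.07 log units; within the scatter), with wide uncertainty. The estimate for compound 4 is 12000 nM, between 4000 nM and 40000 nM.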

Compound 4, half-maximal inhibitory concentration: 33700 nM
For compound 4 the middle estimate is 2.8-fold (0.45 log units) below the measured one; low and high end bracket the measured number.
By their numbers in this assay, from the lowest: compound 1; then compound 3; then compounds 4 and 2 (each within the scatter of the next).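

In this assay, phenyl in place of methyl on this carbonyl carbon gives a clear loss (a 3.3-fold higher number from compound 3 to compound 4 (0.52 log units; beyond the scatter)), and phenyl in place of chloromethyl gives a larger one (a 6.9-fold higher number from compound 1 to compound 4 (0.84 log units; beyond the scatter)). Once benzamido is present, 4-chlorophenyl in place of hydrogen on the saturated chain carbon bound to an amide-type nitrogen changes nothing beyond the scatter (a 1.0-fold lower number from compound 2 to compound 4 (0.01 log units; within the scatter)). Nothing available explains these steps. Open, going by these compounds, is how an aminomethyl group or a longer chain such as propyl on this carbonyl carbon would compare with methyl and phenyl.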